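The source may report more compounds than this note shows. Statements on the series, on what has been measured and on what is new or still open speak of the compounds shown alone.

Compounds measured in an ADME assay on microsomes from liver (Homo sapiens) for metabolic stability, read by LC-MS, using NADPH, tested at 5 uM; on this read-out higher numbers stand for a longer-lived compound and lower numbers for a shorter-lived compound:
compound 1 `Cc1cc(S(=O)(=O)/N=C(\N)n2nccc2-c2ccccc2)c(SCc2ccc(C(F)(F)F)cc2)cc1Cl`: 0.176 h
compound 2 `Cc1cc(S(=O)(=O)/N=C(\N)n2nccc2-c2ccccc2)c(SCc2cccc3ccccc23)cc1Cl`: 0.268 h
compound 3 `Cc1cc(S(=O)(=O)/N=C(\N)n2nccc2-c2ccccc2)c(SCc2cccc(C(F)(F)F)c2)cc1Cl`: 0.0863 h

Compound 3 gives the lowest number of the three in this assay. Compound 4 `Cc1cc(S(=O)(=O)/N=C(\N)n2nccc2-c2ccccc2)c(SCc2ccccc2Cl)cc1Cl` differs from it only in the group carried by the benzylic carbon: 2-chlorophenyl in place of 3-(trifluoromethyl)phenyl on a saturated chain carbon bound to a sulfur. Among the compounds with values here, the steps that bear on this are those which swap the same aryl group: a 2.0-fold lower number from compound 1 to compound 3 (0.31 log units; beyond the scatter) and a 3.1-fold lower number from compound 2 to compound 3 (0.49 log units; beyond the scatter), while a 1.5-fold higher number from compound 1 to compound 2 (0.18 log units; within the scatter). Within the data shown here, exchanging the aryl group thus moves this assay by modest amounts in both directions, and no measured compound carries a chlorine-bearing phenyl here. Compound 4 is therefore expected to sit near compound 3 or somewhat higher, with the step of a 1.4-fold higher number from compound 3 to compound 4 (0.14 log units; within the scatter). The estimate for compound 4 is 0.12 h, in the range 0.06 h to 0.25 h.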

Compound 4, half-life: 0.226 h
The estimate for compound 4 lay 1.9-fold (0.27 log units) below the measured number; measured number inside the range.
By their numbers in this assay, from the lowest: compound 3; then compounds 1, 4 and 2 (each within the scatter of the next).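

In this assay, 2-chlorophenyl on a saturated chain carbon bound to a sulfur gives a 2.6-fold higher number from compound 3 to compound 4 (0.42 log units; beyond the scatter), the first chlorine-bearing phenyl read at this position. Against the other aryl groups, the change gives a 1.2-fold lower number from compound 2 to compound 4 (0.07 log units; within the scatter) and a 1.3-fold higher number from compound 1 to compound 4 (0.11 log units; within the scatter), both within the scatter, which leaves compound 3 alone at the low end among these four compounds. Nothing available accounts for this difference. On these data alone, whether an amine or a carboxylic acid on the phenyl ring, or a longer chain in place of the benzylic carbon, would move the half-life remains open.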